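A few compounds are considered here, and "the series" means these few. Any claim that something is new, unique, unknown or untested is made for them only; others in the source may bear on it.

Measured compounds:
- compound 1, `COc1cc(-c2cc(/C=C/C(=O)c3ccc(N)cc3)[nH]n2)cc(OC)c1OC`: -50% in a functional assay on DU-145 cells (Homo sapiens) for cytotoxicity, read by sulforhodamine B assay, with a stated time of 48 h, tested at 10 uM; a lower number here means a stronger effect, a higher number a weaker effect of the compound at the concentration tested
- compound 2, `COc1ccc(-c2cc(/C=C/C(=O)c3ccc(OC)c(OC)c3)[nH]n2)cc1`: -91% in this assay

Among these two numbers compound 1 stands at the highest, meaning the weaker effect: compound 2 lies a long way lower, and that gap is beyond the scatter. The two compounds differ in more than one place, so their values show only that one is stronger than the other, not which change is responsible.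

Compound 3, `COc1ccc(-c2cc(/C=C/C(=O)c3ccc(N)cc3)[nH]n2)cc1OC`, has not been measured. It is derived from compound 1 by a single change: hydrogen in place of methoxy on an aromatic carbon. The place is on the aromatic ring that carries the other methoxy groups, ortho to one methoxy group and meta to another.

For the measured compounds named here, no step of exactly this kind has been measured here, so the expected size of the step from compound 1 to compound 3 rests on little. A modest move toward a stronger effect in this assay seems plausible, but a step staying within the scatter is equally possible. The expected step is a number 10 percentage points lower from compound 1 to compound 3 (within the scatter). Compound 3 is therefore expected to give about -60%, with a likely range from -85% to -35%.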

Compound 3, a percentage reported as activity, at one concentration (the size of the read-out at that concentration, not a potency): 15%
Beside the measured number, compound 3's estimate is 75 percentage points below it, outside the stated range (above it).
By their numbers in this assay, from the lowest: compound 2; then compound 1; then compound 3.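

In this assay, putting hydrogen in place of methoxy on this one aromatic carbon gives a number 65 percentage points higher from compound 1 to compound 3 (beyond the scatter), so a single small change takes compound 1 at -50% to compound 3 at 15%, a value on the other side of zero. The earlier pair could only show that one compound was stronger than the other, whereas this step ties a large loss of effect to one place: the carbon ortho to a methoxy group and meta to another methoxy group, with a large group meta to it as well. Nothing measured here explains why this methoxy group matters so much in the cells, so the step records an effect and not its cause.

The compounds shown leave open whether a hydroxyl group, an ethoxy group or a fluorine atom at this place would behave more like the methoxy group or more like hydrogen. Compound 2 differs from compound 3 in more than one place, so it cannot show whether this step would be as large in a compound without the amine on the other aromatic ring.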